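Methyl for Methoxy on an Inactive Sulfonamide Pair

The source may report more compounds than this note shows. Statements on the series, on what has been measured and on what is new or still open speak of the compounds shown alone.

compound 1 `CS(=O)(=O)Nc1ccc(-c2nc3ccccc3o2)cc1`: > 63000 nM
compound 2 `COc1cccc(S(=O)(=O)Nc2ccc(-c3nc4ccccc4o3)cc2)c1`: > 63000 nM

Both measured values in an assay on isolated protein for inhibition of malate dehydrogenase, mitochondrial (Sus scrofa), with stated times of 45 min and 30 min (on this read-out higher numbers stand for weaker inhibition and lower numbers for stronger inhibition), are limits of the assay rather than numbers. Compound 1 gives only > 63000 nM in this assay, a limit. Compound 2 gives only > 63000 nM in this assay, likewise a limit. Among the measured compounds shown here, both values sit at the limit of > 63000 nM in this assay, at which 2 of the 2 values shown sit, so the one measured step, a step that the two limits leave unreadable from compound 1 to compound 2, carries no readable size, and compound 2 stands at the limit with no number to place it.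

Compound 3 `Cc1cccc(S(=O)(=O)Nc2ccc(-c3nc4ccccc4o3)cc2)c1` differs from compound 2 by methyl in place of methoxy on an aromatic carbon. For the measured compounds named here, no measured step bears on this change with a readable size: the single step that exists, a step that the two limits leave unreadable from compound 1 to compound 2, is hidden by the two limits. With compound 2 at > 63000 nM in this assay and nothing to suggest a gain, compound 3 is expected to remain at or beyond the limit, the step that the limit leaves unreadable from compound 2 to compound 3 being an expectation only. Compound 3 is therefore estimated at 100000 nM, with a range from 30000 nM to 500000 nM.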

Compound 3, half-maximal inhibitory concentration: > 63000 nM
Compound 3 ended at the assay's limit; the forecaster's own chance of this, stated with the estimate: 85%; the middle value does not contradict the limit.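

No step among compound 1, compound 2 and compound 3 can be read, since each gives only a limit in this assay: the limit of > 63000 nM in this assay, at which 3 of the 3 values shown sit.

The compounds shown leave open how far past its limit each one lies, and so whether methyl, 3-methoxyphenyl and 3-methylphenyl on the sulfonyl sulfur differ at all in this assay.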